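The compounds below may be only part of what the source reports. "The series", "measured", "known", "first", "only" and "open" are said of these compounds alone.

In a functional assay on EOL1 cells (Homo sapiens) for inhibition, read by fluorescence, with a stated time of 72 h (a lower number here means a stronger inhibitor of growth, a higher number a weaker inhibitor of growth), two compounds sharing one core have been measured so far. Compound 1 (`CC(C)CCn1cnc2c(NCc3cccc(Cl)c3)nc(N[C@H]3CC[C@H](N)CC3)nc21`) gives 1330 nM, and compound 2 (`COc1cc(Nc2nc(N[C@H]3CC[C@H](N)CC3)nc3c2ncn3CCC(C)C)cc(OC)c1`) gives 140 nM, the lower of the two numbers. Among the compounds with values here, the only measured step is a 9.5-fold lower number from compound 1 to compound 2 (0.98 log units; beyond the scatter), with 3,5-dimethoxyphenyl in place of 3-chlorobenzyl on a nitrogen on an aromatic ring.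

Compound 3 (`CC(C)CCn1cnc2c(Nc3ccccc3)nc(N[C@H]3CC[C@H](N)CC3)nc21`) differs from compound 2 at that same place, with phenyl in place of 3,5-dimethoxyphenyl on a nitrogen on an aromatic ring. The ring stays on the nitrogen, and only the methoxy groups are gone. Within the data shown here, the one measured step replaced a different group, so it bears on this change only indirectly. Among the measured compounds shown here, no measured pair shows what removing the methoxy groups does on its own. A smaller change than a 9.5-fold lower number from compound 1 to compound 2 (0.98 log units; beyond the scatter) therefore seems likely, tentatively towards a higher number, although the direction remains uncertain. The expected step is a 2.1-fold higher number from compound 2 to compound 3 (0.33 log units; beyond the scatter). For compound 3, the estimated value is 300 nM, with an expected range from 100 nM to 900 nM.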

Compound 3, concentration for 50% growth inhibition: 10 nM
Compound 3: the middle estimate sits 30-fold (1.48 log units) above what was measured, and the stated range ends above it.
By their numbers in this assay, from the lowest: compound 3; then compound 2; then compound 1.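

In this assay, removing only the two methoxy groups gives a 14-fold lower number from compound 2 to compound 3 (1.15 log units; beyond the scatter), so this position on the nitrogen responds strongly to what the aromatic ring carries, and the unsubstituted phenyl gives the lowest number of the series. Replacing the 3-chlorobenzyl group gives a 130-fold lower number from compound 1 to compound 3 (2.12 log units; beyond the scatter), which is larger than a 9.5-fold lower number from compound 1 to compound 2 (0.98 log units; beyond the scatter), so the lower number of compound 2 relative to compound 1 does not depend on having methoxy groups, since compound 3 reaches a lower number without them. Nothing available explains why this small structural change has such a large effect on growth inhibition.

The compounds shown leave open whether a single methoxy group would give a number closer to that of compound 2 or compound 3, and whether a smaller group on the phenyl ring, such as fluorine or hydroxyl, would also raise the number. They also leave open how an unsubstituted benzyl group would compare with phenyl at this nitrogen, which would separate the effect of the extra carbon from that of the chlorine.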